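The source may hold more compounds than are shown below. What is called first, only, known or untested is meant among the compounds shown, and "the series" means these compounds.

Among the compounds with values here, in a functional assay on HFF cells (Homo sapiens) for cytotoxicity (on this read-out higher numbers stand for lower toxicity in this test and lower numbers for higher toxicity in this test), compound 1 `COc1nc(N)nc2c1ncn2/C=C1/C[C@@H]1CO` gives 15800 nM, while compound 2 `C#CCNc1nc(N)nc2c1ncn2/C=C1/C[C@@H]1CO` gives 306000 nM, the higher of the two numbers so far. Compound 3 `CCCCCSc1nc(N)nc2c1ncn2/C=C1/C[C@@H]1CO` has pentylsulfanyl in place of propargylamino on an aromatic carbon. Within the data shown here, only one measured step bears on this change: a 19-fold higher number from compound 1 to compound 2 (1.29 log units; beyond the scatter), with propargylamino in place of methoxy. Taking propargylamino away again may undo much of that large rise, although pentylsulfanyl itself is untested. The expected change is a 20-fold lower number from compound 2 to compound 3 (1.31 log units; beyond the scatter), a large step towards a lower number. The estimated value for compound 3 is 15000 nM, with a range from 3500 nM to 70000 nM.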

Compound 3, half-maximal cytotoxic concentration: 215000 nM
Beside the measured number, compound 3's estimate is 14-fold (1.16 log units) below it; measured number outside the range, above it.
By their numbers in this assay, from the lowest: compound 1; then compounds 3 and 2 (each within the scatter of the next).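

In this assay, the change from propargylamino to pentylsulfanyl on this aromatic carbon is a 1.4-fold lower number from compound 2 to compound 3 (0.15 log units; within the scatter) and so leaves the read-out within the usual scatter. Replacing methoxy with pentylsulfanyl is a 14-fold higher number from compound 1 to compound 3 (1.13 log units; beyond the scatter) and shows that the large rise does not require the triple bond, nitrogen or hydrogen-bond donor of propargylamino, since pentylsulfanyl has none of these. No measured evidence accounts for this result.

From the compounds shown here alone, whether a shorter sulfur group such as methylsulfanyl would stay close to pentylsulfanyl or fall towards methoxy remains open. A longer alkoxy chain such as pentyloxy would show whether the sulfur matters.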